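Swapping the Aromatic Group of Compound 2

This account rests on a few compounds, and the source may have more. Where it says the series, first, only, none or still open, it means among the compounds named here.

- compound 1 `Cn1cc(-c2cnc(NCc3c(F)ccc4c3CCO4)c3cn[nH]c(=O)c23)cn1`: 2.7
- compound 2 `Cc1nc(CO)ccc1-c1cnc(NCc2c(F)ccc3c2CCO3)c2cn[nH]c(=O)c12`: 2.4

In a physicochemical assay for lipophilicity, using the shake flask method, in phosphate buffer, measured as octanol-water partition, with a stated time of 30 min, at pH 7.4 (a higher number here means a more lipophilic compound, a lower number a more polar compound), compound 1 gives 2.7 and compound 2 gives 2.4. These two values cannot be told apart, so compound 2 stands level with compound 1 within the ordinary noise of repeat measurements.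

The next compound, compound 3 `Cc1ncc(-c2cnc(NCc3c(F)ccc4c3CCO4)c3cn[nH]c(=O)c23)n1C`, has not yet been measured. On the same aromatic carbon, 1,2-dimethyl-1H-imidazol-5-yl replaces 6-(hydroxymethyl)-2-methylpyridin-3-yl: 1,2-dimethyl-1H-imidazol-5-yl in place of 6-(hydroxymethyl)-2-methylpyridin-3-yl on an aromatic carbon. The rest of the molecule stays the same.

For the measured compounds named here, only one measured step bears on this change: a number 0.30 log units lower from compound 1 to compound 2 (within the scatter). It involves the same aromatic carbon, but it brings in a different group, so it is only a rough guide. Exchanging one aromatic group for another at this place has so far produced no step beyond the scatter, although this rests on a single pair. The expected result is therefore a number 0.10 log units lower from compound 2 to compound 3 (within the scatter), with no step beyond the scatter anticipated in this assay. For compound 3, the estimated value is 2.3, within an expected range of 1.8 to 2.8.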

Compound 3, distribution coefficient: 1.9
The estimate for compound 3 lay 0.40 log units above the measured number; measured number inside the range.
By their numbers in this assay, from the lowest: compound 3; then compounds 2 and 1 (each within the scatter of the next).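

In this assay, the group on this aromatic carbon can now be seen to shift the number beyond the scatter, which the earlier pair did not show. Placing 1,2-dimethyl-1H-imidazol-5-yl here gives a number 0.50 log units lower from compound 2 to compound 3 (beyond the scatter) and, against 1-methyl-1H-pyrazol-4-yl, a number 0.80 log units lower from compound 1 to compound 3 (beyond the scatter) as well, so compound 3 sits lowest of the three, with both steps beyond the scatter and both modest in size. The lowest number therefore belongs to a compound whose entering group has 0 hydrogen-bond donors, while the 6-(hydroxymethyl)-2-methylpyridin-3-yl group it replaces has 1, so the donor count alone does not order these compounds.

The step from compound 2 changes the ring size, the hetero atoms and the hydroxymethyl group all at once, and the compounds shown cannot separate these parts. They also leave open where the number would fall with an amine or a carboxylic acid on the ring at this aromatic carbon, or with a longer chain in place of the methyl groups of 1,2-dimethyl-1H-imidazol-5-yl.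

No measurement at hand accounts for the size of either step.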